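The compounds below may be only part of what the source reports. "The series", "measured", "known", "first", "only" and "open" are said of these compounds alone.

Of the compounds shown here, three built on one shared core have been tested in a physicochemical assay for solubility, in phosphate buffer, measured as kinetic solubility, at pH 7.4; on this read-out higher numbers stand for higher solubility and lower numbers for lower solubility. Compound 2 `Cc1ccccc1-c1nc(CN2CCC(C(=O)NCCCN3CCC(C)(C)CC3)CC2)c(C)o1` gives > 69 ug/mL, which is a limit rather than a number. Compound 1 `Cc1ccccc1-c1nc(CN2CCC(C(=O)NCCCN3CCC(C(C)C)CC3)CC2)c(C)o1` gives > 71 ug/mL, again a limit. Compound 3 `Cc1cccc(Cl)c1-c1nc(CN2CCC(C(=O)NCCCN3CCC(C)(C)CC3)CC2)c(C)o1` gives > 74 ug/mL, likewise a limit. The change from compound 2 to compound 1 is 4-isopropylpiperidin-1-yl in place of 4,4-dimethylpiperidin-1-yl on a saturated chain carbon, three bonds along the chain from an amide-type nitrogen, and its step is a step that the two limits leave unreadable from compound 2 to compound 1. The cores of compound 2 and compound 3 differ by chloro in place of hydrogen on an aromatic carbon, with a step that the two limits leave unreadable from compound 2 to compound 3. Compound 4 `Cc1cccc(Cl)c1-c1nc(CN2CCC(C(=O)NCCCN3CCC(C(C)C)CC3)CC2)c(C)o1` has not been measured; it differs from compound 3 by 4-isopropylpiperidin-1-yl in place of 4,4-dimethylpiperidin-1-yl on a saturated chain carbon, three bonds along the chain from an amide-type nitrogen, the same change as from compound 2 to compound 1, at the same place. Compound 3 sits at the limit of > 74 ug/mL in this assay, at which 1 of the 3 values shown sits, and compound 1 at the limit of > 71 ug/mL in this assay, at which 1 of the 3 values shown sits. On that basis the step is expected to be a step that the limit leaves unreadable from compound 3 to compound 4. Compound 4 is estimated to give 80 ug/mL in this assay, most probably reported again only as a limit.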

Compound 4, solubility: > 76 ug/mL
Compound 4 gave a limit, no number; the forecaster's own chance of this, stated with the estimate: 85%; the middle value lies beyond the limit too.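

Compound 1, compound 3 and compound 4 all give only limits in this assay, so neither step to compound 4 can be read. The compounds shown leave open whether either change alters solubility at all.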